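Bromophenyl replacing methoxyphenyl on a shared core

The compounds below may be only part of what the source reports. "The series", "measured", "known", "first", "only" and "open" are said of these compounds alone.

Compound 3 `C=CCn1c(=O)/c(=C\c2ccccc2OC)[nH]c(=O)/c1=C\c1ccccc1OC` stands second highest of the three numbers measured in a functional assay on Huh-7 cells (Homo sapiens) for cytotoxicity, read by CCK-8 assay, with a stated time of 72 h (a higher number here means a weaker inhibitor, a lower number a stronger inhibitor), where compound 3 gives 21200 nM. Compound 1 `C=CCn1c(=O)/c(=C\c2cccc(Cl)c2)[nH]c(=O)/c1=C\c1ccccc1OC` gives 8900 nM in this assay, and compound 2 `C=CCn1c(=O)/c(=C\c2cccc(F)c2)[nH]c(=O)/c1=C\c1ccccc1OC` gives 27200 nM. Compound 4 `C=CCn1c(=O)/c(=C\c2cccc(Br)c2)[nH]c(=O)/c1=C\c1ccccc1OC` is not yet measured; it differs from compound 3 by 3-bromophenyl in place of 2-methoxyphenyl on a double-bonded chain carbon bound to an aromatic carbon. Going by the values given here, two measured steps bear on this change: the step of a 2.4-fold higher number from compound 1 to compound 3 (0.38 log units; beyond the scatter), in which 2-methoxyphenyl replaced 3-chlorophenyl, and the step of a 1.3-fold lower number from compound 2 to compound 3 (0.11 log units; within the scatter). The step of a 3.1-fold higher number from compound 1 to compound 2 (0.49 log units; beyond the scatter) shows the two halogens apart. Bromo, like chloro, is a halogen, so a modestly lower number is expected for compound 4 in this assay, estimated as a 3.0-fold lower number from compound 3 to compound 4 (0.48 log units; beyond the scatter). Compound 4 is estimated at 7000 nM, with a range from 2500 nM to 20000 nM.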

Compound 4, half-maximal inhibitory concentration: 2300 nM
Compound 4: the middle estimate sits 3.0-fold (0.48 log units) above what was measured; measured number below the stated range.
By their numbers in this assay, from the lowest: compound 4; then compound 1; then compounds 3 and 2 (each within the scatter of the next).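

Among the halogens on this aromatic carbon, bromo goes further than chloro in this assay, with bromo in place of chloro giving a 3.9-fold lower number from compound 1 to compound 4 (0.59 log units; beyond the scatter) and bromo in place of fluoro giving a 12-fold lower number from compound 2 to compound 4 (1.07 log units; beyond the scatter). The number therefore falls from fluoro through chloro to bromo across these three compounds, and compound 4 is the lowest of the four. Swapping 2-methoxyphenyl for 3-bromophenyl gives a 9.2-fold lower number from compound 3 to compound 4 (0.96 log units; beyond the scatter).

No measurement here explains this order. Going by these compounds, whether iodo in this place would lower the number further, and how an amine would compare, remains open.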